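From 2-hydroxyethyl to 2-methoxyethyl in compound 2

The source may report more compounds than this note shows. Statements on the series, on what has been measured and on what is new or still open speak of the compounds shown alone.

Measured in an ADME assay on the whole organism (plasma, strain CD) for pharmacokinetics, with Rattus norvegicus as the target, at a dose of 5 mg/kg by the oral route; a higher number here means more compound in the circulation at the dose given, a lower number less compound in the circulation:
compound 1 `C[C@H](CO)NC(=O)c1c(O)c2ncc(Cc3ccc(F)cc3)cc2[nH]c1=O`: 6370 ng.h/mL
compound 2 `O=C(NCCO)c1c(O)c2ncc(Cc3ccc(F)cc3)cc2[nH]c1=O`: 3060 ng.h/mL
compound 3 `Cn1c(=O)c(C(=O)NCCO)c(O)c2ncc(Cc3ccc(F)cc3)cc21`: 22800 ng.h/mL

Compound 2 stands lowest of the three in this assay. Compound 4 `COCCNC(=O)c1c(O)c2ncc(Cc3ccc(F)cc3)cc2[nH]c1=O` turns its 2-hydroxyethyl into 2-methoxyethyl, with methyl in place of hydrogen on an oxygen on a saturated carbon.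

Within the data shown here, no measured step places a methyl on this oxygen, so the evidence is indirect. Among the measured compounds shown here, two steps bear on the change. Methyl in place of hydrogen on an aromatic nitrogen gave a 7.5-fold higher number from compound 2 to compound 3 (0.87 log units; beyond the scatter). Hydrogen in place of methyl on a saturated chain carbon gave a 2.1-fold lower number from compound 1 to compound 2 (0.32 log units; beyond the scatter). In both pairs the compound with the additional methyl has the higher number, so a rise of modest size is expected in this assay. The estimated change is a 2.0-fold higher number from compound 2 to compound 4 (0.29 log units; within the scatter), close to the smaller measured step. For compound 4 the expected value is 6000 ng.h/mL, with an estimated range of 1800 ng.h/mL to 20000 ng.h/mL.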

Compound 4, area under the concentration-time curve: 1650 ng.h/mL
Estimate against measurement, compound 4: 3.6-fold (0.56 log units) above, outside the stated range (below it).
By their numbers in this assay, from the lowest: compounds 4 and 2 (each within the scatter of the next); then compound 1; then compound 3.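

Methyl in place of hydrogen on an oxygen on a saturated carbon gives a 1.9-fold lower number from compound 2 to compound 4 (0.27 log units; within the scatter) in this assay, so hydroxy to methoxy at this position does not separate the two compounds and does not repeat a 7.5-fold higher number from compound 2 to compound 3 (0.87 log units; beyond the scatter). The benefit of an added methyl in this series therefore depends on where it stands: on the aromatic nitrogen it counts, and on this oxygen it does not. Against the branched side chain the change reads a 3.9-fold lower number from compound 1 to compound 4 (0.59 log units; beyond the scatter), which leaves 2-methoxyethyl clearly short of 1-(hydroxymethyl)ethyl on the amide-type nitrogen, and nothing available accounts for these numbers.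

Still open, going by these compounds, is how an amine or a carboxylic acid at the end of this chain, or a longer chain, would read in this assay. Also open, on these data alone, is whether 2-methoxyethyl keeps the high number of compound 3 when combined with methyl on the aromatic nitrogen.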